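Fluoro step from compound 2 to compound 3

A few compounds are considered here, and "the series" means these few. Any claim that something is new, unique, unknown or untested is made for them only; others in the source may bear on it.

- Compound 1 `O=C(Nc1cccc(-c2nc3ccccc3s2)c1)c1cc([N+](=O)[O-])c(O)cc1Cl` in an ADME assay on HEK293 cells (Homo sapiens) for cytotoxicity, with a stated time of 72 h (a lower number here means that less compound is needed, a higher number that more compound is needed for the effect), gives > 25000 nM as a limit
- Compound 2 `O=C(Nc1cccc(-c2nc3ccccc3s2)c1)c1cc([N+](=O)[O-])ccc1Cl` in this assay gives > 27000 nM as a limit

Compound 2 has no number, only the limit > 27000 nM in this series. Compound 3 `O=C(Nc1cc(-c2nc3ccccc3s2)ccc1F)c1cc([N+](=O)[O-])ccc1Cl` differs from compound 2 by fluoro in place of hydrogen on an aromatic carbon with fluoro in place of hydrogen on an aromatic carbon. Among the compounds with values here, the only measured step is a step that the two limits leave unreadable from compound 1 to compound 2 and it is a different change, so no measured size bears on fluoro. No step beyond the scatter is expected in this assay for this change. The estimated move is a number no higher from compound 2 to compound 3 (the limit leaves the size open) with no direction expected. Compound 3 is estimated at 27000 nM with an expected range from 13000 nM to 55000 nM and probably only a limit reported.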

Compound 3, half-maximal effective concentration: > 25000 nM
Compound 3: only a limit was reported; the forecaster's own chance of this, stated with the estimate: 80%; the middle value is on the limit's open side.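

In this assay compound 2 gives > 27000 nM as a limit. Compound 3 gives > 25000 nM, also a limit, so no step can be read between compound 2 and compound 3. The compounds shown leave open what size of effect fluoro in place of hydrogen has here.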